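The compounds below may be only part of what the source reports. "The series", "measured", "known", "first", "only" and "open" are said of these compounds alone.

Series notes. The shared core carries an amide-linked substituent bearing a sulfanyl chain, and the end of that chain is the point of variation. Compound 1 is `CC(C(=O)NCc1ccc(C(F)(F)F)nc1SCCCO)c1ccc(NS(C)(=O)=O)c(F)c1`; in an assay on CHO-K1 cells for antagonist activity at transient receptor potential cation channel subfamily V member 1 (Homo sapiens), read by FLIPR (a lower number here means a stronger inhibitor, a higher number a weaker inhibitor), compound 1 is reported as "not active" (no number reported), with no number given. Compound 2 is `CC(C(=O)NCc1ccc(C(F)(F)F)nc1SCCCN1CCCCC1)c1ccc(NS(C)(=O)=O)c(F)c1`; in this assay compound 2 gives 3 nM. On the numbers shown, compound 2 holds the only measured value; the one further entry, compound 1, carries no single number, so no step between measured compounds can be stated.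

Compound 3 is `CC(C(=O)NCc1ccc(C(F)(F)F)nc1SCCC(=O)O)c1ccc(NS(C)(=O)=O)c(F)c1`, not yet measured. Relative to compound 2 the change is carboxy in place of (piperidin-1-yl)methyl on a saturated chain carbon, two bonds along the chain from a sulfur. The (piperidin-1-yl)methyl group leaves and a carboxy group enters, so that the (3-(piperidin-1-yl)propyl)sulfanyl chain becomes a (2-carboxyethyl)sulfanyl chain.

Expectation: a step well beyond the scatter toward a weaker inhibitor, since compound 1, which likewise lacks the piperidin-1-yl group, gives "not active" (no number reported). For compound 3 in this assay the estimate is 3000 nM, with a range of 300 nM to 30000 nM. The expected step is a 1000-fold higher number from compound 2 to compound 3 (3.00 log units; beyond the scatter), and there is a real chance that only a limit and no number is returned.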

Compound 3, inhibition constant: "not active" (no number reported)
Nothing numeric was reported for compound 3; there is nothing to compare the estimate with.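

No step can be read from compound 2 to compound 3, since in this assay compound 3 gives "not active" (no number reported) and so offers no number for comparison. Nothing shown bears on the reason for this result. The compounds shown leave open whether any chain end lacking the piperidin-1-yl group returns a number in this assay.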